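Benzoyl for phenylsulfonyl: working notes toward compound 4

The compounds below may be only part of what the source reports. "The series", "measured", "known", "first", "only" and "open" are said of these compounds alone.

Measured so far in a functional assay on SF-295 cells (Homo sapiens) for inhibition, read by sulforhodamine B assay, with a stated time of 48 h; on this read-out higher numbers stand for weaker inhibition of growth and lower numbers for stronger inhibition of growth:
- compound 1 `COc1ccc(-c2[nH]c3ccccc3c2/C=C(\C#N)S(=O)(=O)c2ccccc2)cc1` gives 500 nM
- compound 2 `CC(=O)/C(=C\c1c(-c2ccccc2)[nH]c2ccccc12)S(=O)(=O)c1ccccc1` gives 2400 nM
- compound 3 `N#C/C(=C\c1c(-c2ccccc2)[nH]c2ccccc12)S(=O)(=O)c1ccccc1` gives 2400 nM

Compound 3 sits level with compound 2 at the digits shown; the two share the highest number of the three. Going by the values given here, its only step beyond the scatter is to compound 1: a 4.8-fold higher number from compound 1 to compound 3 (0.68 log units; beyond the scatter), the sole difference there being hydrogen in place of methoxy on an aromatic carbon. The other step into compound 3, no change at the digits printed from compound 2 to compound 3 (within the scatter), exchanges the substituent on the chain carbon without moving the number.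

Compound 4 `N#C/C(=C\c1c(-c2ccccc2)[nH]c2ccccc12)C(=O)c1ccccc1` differs from compound 3 in one place: benzoyl in place of phenylsulfonyl on a double-bonded chain carbon bound to a double-bonded chain carbon and a triple-bonded carbon. Among the compounds with values here, no measured pair exchanges this group, so neither step bears on it directly. Within the data shown here, the nearest guidance is the exchange at the neighbouring chain carbon, which left the number unchanged, while the one clearly resolved step in this set came from a ring substituent far from the chain. On this basis a step of modest size at most is expected for compound 4 in this assay, with no clear direction; the estimate is a 1.3-fold higher number from compound 3 to compound 4 (0.10 log units; within the scatter).

The expected value for compound 4 is 3000 nM, within 1000 nM to 10000 nM.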

Compound 4, concentration for 50% growth inhibition: 3000 nM
Compound 4: the middle estimate sits on the measured number at the digits printed, and the stated range covers the measured number.
By their numbers in this assay, from the lowest: compound 1; then compounds 2, 3 and 4 (each within the scatter of the next).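

In this assay, the exchange of phenylsulfonyl for benzoyl gives a 1.3-fold higher number from compound 3 to compound 4 (0.10 log units; within the scatter), so with the nitrile kept on this chain carbon, the sulfonyl sulfur can be removed without a resolved shift in the number. The earlier exchange on the same carbon, with phenylsulfonyl kept, gave no change at the digits printed from compound 2 to compound 3 (within the scatter), so both substituents on this carbon have now been varied once, and neither step leaves the scatter, although each tests a single replacement only. No measurement shown explains why the number holds across these exchanges.

The only step beyond the scatter remains the one involving the aromatic methoxy group, a 4.8-fold higher number from compound 1 to compound 3 (0.68 log units; beyond the scatter), and the compounds shown leave open whether that methoxy group would give a similar step on the benzoyl compound 4. Also open, as far as these compounds go, is whether the tolerance seen at this chain carbon extends past acetyl, nitrile, phenylsulfonyl and benzoyl to an amide or a carboxylic acid, or to a longer alkyl ketone in place of benzoyl.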